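Chloro ortho to the core: expected shift in binding

The compounds below may be only part of what the source reports. "The series", "measured", "known", "first", "only" and "open" are said of these compounds alone.

Among the compounds with values here, compound 1 `COC(=O)C1=C(c2ccccc2)C2CCC1C2` gives 646000 nM in an in vitro assay on COS-1 cells for inhibition of sodium-dependent dopamine transporter (Homo sapiens) (a higher number here means a weaker inhibitor, a lower number a stronger inhibitor), the higher of the two numbers measured so far. The nearest is compound 2 `COC(=O)C1=C(c2ccc(-c3ccccc3)cc2)C2CCC1C2`, which gives 603000 nM; the step of a 1.1-fold lower number from compound 1 to compound 2 (0.03 log units; within the scatter) came with phenyl in place of hydrogen on an aromatic carbon and lies within the scatter. Compound 3 `COC(=O)C1=C(c2ccccc2Cl)C2CCC1C2` differs from compound 1 by chloro in place of hydrogen on an aromatic carbon, placed on an aromatic carbon of the six-membered aromatic ring of carbon only, ortho to a large group. Within the data shown here, no measured step covers a chloro entering this ring; the only step on the ring, a 1.1-fold lower number from compound 1 to compound 2 (0.03 log units; within the scatter), was within the scatter, so the data give no ground for a large move in either direction. Compound 3 is therefore expected near compound 1, at roughly 450000 nM in this assay, within 120000 nM to 1500000 nM. The expected step of a 1.4-fold lower number from compound 1 to compound 3 (0.16 log units; within the scatter) is small and uncertain in sign.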

Compound 3, inhibition constant: 372000 nM
For compound 3 the middle estimate is 1.2-fold (0.08 log units) above the measured one, and the stated range covers the measured number.
By their numbers in this assay, from the lowest: compounds 3, 2 and 1 (each within the scatter of the next).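

In this assay, within the data shown here, chloro in place of hydrogen on an aromatic carbon, ortho to a large group, gives a 1.7-fold lower number from compound 1 to compound 3 (0.24 log units; within the scatter), so this is the first reading at this position, and a chlorine there brings no step beyond the scatter. The earlier ring change, a 1.1-fold lower number from compound 1 to compound 2 (0.03 log units; within the scatter), also lies within the scatter, so neither of the two ring substitutions shown separates its compound from compound 1. No measurement available here accounts for the size of either step.

As far as these compounds go, whether an amine or a carboxylic acid at this same position would also stay within the scatter of compound 1 remains open. Also open, from the compounds shown here alone, is whether replacing the methyl ester on the shared core with an amide would move the number further than any change on the ring has so far.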